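Series notes: urea versus direct amide link to trifluoromethylphenyl

The compounds below may be only part of what the source reports. "The series", "measured", "known", "first", "only" and "open" are said of these compounds alone.

compound 1 `COc1cc(Cl)cc(-c2nn(-c3cccc(NC(=O)Nc4ccc(Cl)c(Cl)c4)c3)cc2-c2ccncc2)c1`: -36%
compound 2 `COc1cc(Cl)cc(-c2nn(-c3cccc(NC(=O)Nc4cccc(C(F)(F)F)c4)c3)cc2-c2ccncc2)c1`: -72%

In a functional assay on UACC-257 cells (Homo sapiens) for inhibition, read by sulforhodamine B assay, with a stated time of 48 h, tested at 100 uM (a lower number here means a stronger effect, a higher number a weaker effect of the compound at the concentration tested), compound 2 gives -72%, the lowest of the two numbers; the nearest is compound 1 at -36%. Among the compounds with values here, the only measured step, a number 36 percentage points lower from compound 1 to compound 2 (beyond the scatter), exchanges the aryl on the amide-type nitrogen and leaves the urea link untouched. Compound 3 `COc1cc(Cl)cc(-c2nn(-c3cccc(NC(=O)c4cccc(C(F)(F)F)c4)c3)cc2-c2ccncc2)c1` differs from compound 2 by 3-(trifluoromethyl)phenyl in place of (3-(trifluoromethyl)phenyl)amino on a carbonyl carbon. Within the data shown here, no measured step bears on this change of the link itself, so no direction can be taken from the data. Compound 3 is therefore expected near compound 2, estimated at -55% with a wide range from -90% to 0%, an expected step of a number 17 percentage points higher from compound 2 to compound 3 (beyond the scatter).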

Compound 3, a percentage reported as activity, at one concentration (the size of the read-out at that concentration, not a potency): 52%
For compound 3 the middle estimate is 107 percentage points below the measured one; measured number above the stated range.
By their numbers in this assay, from the lowest: compound 2; then compound 1; then compound 3.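

At this carbonyl carbon the link carries more weight than the first two compounds could show: 3-(trifluoromethyl)phenyl in place of (3-(trifluoromethyl)phenyl)amino gives a number 124 percentage points higher from compound 2 to compound 3 (beyond the scatter) in this assay, and the comparison with the 3,4-dichlorophenyl urea gives a number 88 percentage points higher from compound 1 to compound 3 (beyond the scatter). Of the compounds shown, only the direct amide, compound 3, has a positive number, while both ureas have negative ones. No measurement available here accounts for this difference. Open, going by these compounds, is whether a sulfonamide link or a methylene chain between the carbonyl and the aryl would give negative numbers.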